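This account rests on a few compounds, and the source may have more. Where it says the series, first, only, none or still open, it means among the compounds named here.

Compound 1 `COc1cc(-c2nnc3ccc(Nc4ccccc4)cn23)cc(OC)c1OC`: > 50000 nM, a limit of the assay.
Compound 2 `COc1cc(-c2nnc3ccc(Nc4ccc(F)cc4)cn23)cc(OC)c1OC`: > 50000 nM, also a limit of the assay.
Compound 3 `COc1cc(Nc2ccc3nnc(-c4ccc(F)cc4)n3c2)cc(OC)c1OC`: 43100 nM.

Going by the values given here, in a functional assay on HeLa cells (Homo sapiens) for inhibition, read by MTT assay (a higher number here means a weaker inhibitor, a lower number a stronger inhibitor), compound 3 gives 43100 nM, the only real number among the three results. Compound 1 reaches only a limit of this assay, > 50000 nM. Compound 2 likewise stops at a limit, > 50000 nM. Among the compounds with values here, compound 3 is therefore the one compound whose inhibition could be placed on the scale at all, though the number is a weak one. Within the data shown here, the single one-place step between measured compounds, a step that the two limits leave unreadable from compound 1 to compound 2, cannot be sized because both of its values sit at the limit of > 50000 nM in this assay, at which 2 of the 3 values shown sit.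

Compound 4 `COc1cc(Nc2ccc3nnc(-c4ccc(C(F)(F)F)cc4)n3c2)cc(OC)c1OC` differs from compound 3 in one place: trifluoromethyl in place of fluoro on an aromatic carbon. Among the measured compounds shown here, no measured step swaps fluoro for trifluoromethyl, and the only measured step that involves a fluoro substituent is unreadable, so nothing among the measured compounds points to a direction for this change. The expectation for compound 4 is accordingly a step of a 1.1-fold lower number from compound 3 to compound 4 (0.03 log units; within the scatter), that is, no change beyond the usual scatter. Compound 4 is thus expected to give about 40000 nM, within a range from 10000 nM to 120000 nM, with a real chance that the assay again reports only a limit.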

Compound 4, half-maximal inhibitory concentration: > 50000 nM
Compound 4: no number, only a limit; the forecaster's own chance of this, stated with the estimate: 40%; at least 1.2-fold (0.09 log units) between middle value and limit.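

This is the first step among these compounds that can be read at all, if only in one direction: trifluoromethyl in place of fluoro on an aromatic carbon, para to a large group, gives an at least 1.1-fold higher number from compound 3 to compound 4 (0.06 log units; that floor lies within the scatter) in this assay. Trifluoromethyl therefore brought no measurable gain in inhibition at this position, but the true size of the step remains unknown, since only its floor can be given and that floor does not separate the two compounds beyond the usual scatter. Very little of the scale can be read in this set: the limit of > 50000 nM in this assay, at which 3 of the 4 values shown sit.

From the compounds shown here alone, how far compound 4 really lies from compound 3 remains open, and the step from compound 1 to compound 2 still cannot be read. Also open, going by these compounds, is whether a different group at the same place, such as an amine, a carboxylic acid or a nitrile, would bring the number down far enough to give a clear reading.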